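Replacing benzyl with 3,4-dihydroxyphenyl in the series

The source may hold more compounds than are shown below. What is called first, only, known or untested is meant among the compounds shown, and "the series" means these compounds.

Compound 1 `O=C(NCCNS(=O)(=O)c1sccc1-c1ccccc1Oc1ccc(O)c(O)c1)Nc1cc(Cl)cc(Cl)c1`: > 50000 nM, a limit
Compound 2 `O=S(=O)(NCCNC(=S)Nc1cc(C(F)(F)F)cc(C(F)(F)F)c1)c1ccc(-c2ccccc2O[C@H]2CC[C@@H](O)CC2)s1`: 10900 nM
Compound 3 `O=S(=O)(NCCNC(=S)Nc1cc(C(F)(F)F)cc(C(F)(F)F)c1)c1ccc(-c2ccccc2OCc2ccccc2)s1`: 4700 nM
Compound 4 `O=S(=O)(NCCNC(=S)Nc1cc(C(F)(F)F)cc(C(F)(F)F)c1)c1ccc(-c2ccccc2Oc2ccc(O)c(O)c2)s1`: not yet measured

All values come from a functional assay on HeLa cells (Homo sapiens) for inhibition, read by CCK-8 assay, with a stated time of 48 h; on this read-out higher numbers stand for weaker inhibition and lower numbers for stronger inhibition. Compound 3 gives 4700 nM, the lower of the two actual numbers. The next step is 3,4-dihydroxyphenyl in place of benzyl on an oxygen on an aromatic ring, in words 3,4-dihydroxyphenyl in place of benzyl on an oxygen on an aromatic ring.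

One measured step changes this same place: a 2.3-fold lower number from compound 2 to compound 3 (0.37 log units; beyond the scatter), with benzyl in place of 4-hydroxycyclohexyl. Exchange at this place has therefore moved the number only modestly so far. Compound 1 also carries 3,4-dihydroxyphenyl on that oxygen but differs from compound 4 elsewhere, so it offers only weak guidance. The value of compound 1 is a limit: > 50000 nM.

On this evidence, a modest move toward weaker inhibition in this assay is expected, with some chance of a larger one. The expected change is a 1.9-fold higher number from compound 3 to compound 4 (0.28 log units; within the scatter). For compound 4 the estimated value is 9000 nM, with an expected range of 3500 nM to 30000 nM.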

Compound 4, half-maximal inhibitory concentration: > 20000 nM
Compound 4 gave a limit, no number; the forecaster's own chance of this, stated with the estimate: 12%; middle value at least 2.2-fold (0.34 log units) from the limit.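

In this assay, putting 3,4-dihydroxyphenyl in place of benzyl on this oxygen gives an at least 4.2-fold higher number from compound 3 to compound 4 (0.62 log units; beyond the scatter), so this place does not accept every aromatic group equally, and an aromatic ring alone does not hold the number near that of compound 3. Set against the 4-hydroxycyclohexyl group, the same exchange gives an at least 1.8-fold higher number from compound 2 to compound 4 (0.26 log units; that floor lies within the scatter), a floor that supports no order between those two groups. The value of compound 4 is a limit, so the full size of both steps stays unread: the limit of > 20000 nM in this assay, at which 1 of the 4 values shown sits.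

The compounds shown leave open whether the step follows the two hydroxyl groups or the loss of the carbon link that benzyl places between oxygen and ring. A plain phenyl, a 3,4-dimethoxyphenyl or a 3,4-dihydroxybenzyl group on this oxygen would separate the two.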